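The compounds below may be only part of what the source reports. "The series", "measured", "known", "first", "only" and "open" are said of these compounds alone.

Measured compounds:
compound 1 `COc1cc(F)ccc1-c1ccnc2[nH]c(C3CCN(CC(=O)N(C)C)CC3)cc12` 38 uL/min
compound 2 `CC(C)n1cc(-c2ccnc3[nH]c(C4CCN(CC(=O)N(C)C)CC4)cc23)cnc1=O` 100 uL/min
compound 3 `COc1cc(=O)n(C)cc1-c1ccnc2[nH]c(C3CCN(CC(=O)N(C)C)CC3)cc12` < 1 uL/min

In an ADME assay on cells (Hepatocyte, Rattus norvegicus) for metabolic stability (a higher number here means faster removal of the compound, a lower number slower removal), compound 1 gives 38 uL/min and compound 2 gives 100 uL/min, a change of a 2.6-fold higher number from compound 1 to compound 2 (0.42 log units; beyond the scatter). Going by the values given here, compound 3 stands apart from both: its value of < 1 uL/min is a limit of this assay, not a number, and it is the one value of the three that sits there (the limit of < 1 uL/min in this assay, at which 1 of the 3 values shown sits). The change from compound 1 to compound 3 is an at least 38-fold lower number from compound 1 to compound 3 (1.57 log units; beyond the scatter), and that from compound 2 to compound 3 is an at least 100-fold lower number from compound 2 to compound 3 (2.00 log units; beyond the scatter).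

Compound 4 `CN(C)C(=O)CN1CCC(c2cc3c(-c4ccc(=O)n(C)c4)ccnc3[nH]2)CC1` differs from compound 3 in one place: hydrogen in place of methoxy on an aromatic carbon. Among the compounds with values here, none of the measured steps removes a methoxy on its own; the two steps that reach compound 3 each swap a whole ring group, so they bound only the step into compound 3 and say nothing about the methoxy itself. Since compound 3 stands at a limit, the step to compound 4 cannot be measured downward, and an expected step of an at least 2.0-fold higher number from compound 3 to compound 4 (0.30 log units; that floor lies within the scatter) rests on little. The estimate for compound 4 in this assay is 2 uL/min, with a range from 0.5 uL/min to 10 uL/min.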

Compound 4, intrinsic clearance in a liver preparation (reported as CLH), per the amount of preparation that the assay uses in the Hepatocyte assay: < 1 uL/min
Compound 4: only a limit was reported; the forecaster's own chance of this, stated with the estimate: 40%; middle value at least 2.0-fold (0.30 log units) away from the limit.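

In the Hepatocyte assay, the methoxy turns out not to be needed for the low number: with hydrogen on that aromatic carbon the ring group still gives an at least 100-fold lower number from compound 2 to compound 4 (2.00 log units; beyond the scatter) and an at least 38-fold lower number from compound 1 to compound 4 (1.57 log units; beyond the scatter), while the step between compound 3 and compound 4 cannot be read, as both stand at a limit. In a physicochemical assay for solubility, in phosphate buffer, at pH 7.4 (a lower number here means a less soluble compound, a higher number a more soluble compound), compound 3 gives 670000 nM. In the physicochemical assay compound 4 gives > 1000000 nM, which is a limit of the assay and not a number: the limit of > 1000000 nM in the physicochemical assay, at which 1 of the 2 values shown sits.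

The compounds shown leave open whether another group on this carbon, such as an amine or a longer alkoxy chain, would bring the number in the Hepatocyte assay off its limit. Going by these compounds alone, in the physicochemical assay the only reading of the change is a floor, an at least 1.4-fold higher number from compound 3 to compound 4 (0.17 log units; that floor lies within the scatter), so its true size also stays open.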